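Aryl swap on the shared core: what compound 4 should give

A few compounds are considered here, and "the series" means these few. Any claim that something is new, unique, unknown or untested is made for them only; others in the source may bear on it.

Measured compounds:
Compound 1, `COc1ccc(C2CC(c3ccc(Br)cc3)=NN2C(=O)C2COc3ccccc3O2)cc1`, gives 9010 nM in a functional assay on WM 266-4 cells (Homo sapiens) for inhibition, read by MTT assay, with a stated time of 24 h; on this read-out higher numbers stand for weaker inhibition of growth and lower numbers for stronger inhibition of growth.
Compound 2, `COc1ccc(C2=NN(C(=O)C3COc4ccccc4O3)C(c3ccc(OC)cc3)C2)cc1`, gives 11000 nM in this assay.
Compound 3, `COc1ccc(C2CC(c3ccc(Br)cc3)=NN2C(=O)c2ccc3c(c2)OCCO3)cc1`, gives 5680 nM in this assay.

Among the measured compounds shown here, compound 1 sits among three numbers that are all within the usual scatter of one another: the step of a 1.2-fold higher number from compound 1 to compound 2 (0.09 log units; within the scatter) and the step of a 1.6-fold lower number from compound 1 to compound 3 (0.20 log units; within the scatter) both stay inside that band, so no compound of the three can be set apart from another.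

Compound 4, `O=C(C1COc2ccccc2O1)N1N=C(c2ccc(Br)cc2)CC1c1cccc(F)c1`, has not been measured in this assay. It differs from compound 1 in one place: 3-fluorophenyl in place of 4-methoxyphenyl on a saturated ring carbon. Neither measured step touches that position. The step from compound 1 to compound 2 changes a group on the 4-bromophenyl ring, and the step from compound 1 to compound 3 changes the group on the carbonyl carbon; both were within the scatter. For the measured compounds named here, the data therefore hold no step that bears directly on the change to compound 4, and nothing here argues for a move beyond the scatter in either direction.

Compound 4 is therefore expected to lie close to compound 1, with a step of a 1.1-fold lower number from compound 1 to compound 4 (0.03 log units; within the scatter). The estimate for compound 4 in this assay is 8500 nM, with a range from 3000 nM to 24000 nM.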

Compound 4, concentration for 50% growth inhibition: 7810 nM
Compound 4: middle estimate off by 1.1-fold (0.04 log units), on the high side, within the range that was stated.
By their numbers in this assay, from the lowest: compounds 3, 4, 1 and 2 (each within the scatter of the next).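

Compound 4 is the first of these compounds to change the aryl group on the saturated ring carbon next to the ring nitrogen, a position that neither earlier step touched. In this assay, the exchange of 4-methoxyphenyl for 3-fluorophenyl gives a 1.2-fold lower number from compound 1 to compound 4 (0.06 log units; within the scatter), so this one change at this position stays inside the scatter, although the leaving group counts 1 hydrogen-bond acceptor and the entering group 0. Nothing on hand accounts for this result.

The step alters the substituent and its place on the ring together, so the compounds shown cannot separate the loss of methoxy from the arrival of fluorine, nor say how a 3-methoxyphenyl or a 4-fluorophenyl group would read. They also leave open whether a group of another kind on this carbon, such as a pyridyl ring, a cyclohexyl ring or a phenyl ring carrying a carboxylic acid or an amine, would move the number beyond the scatter.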